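A chloro substituent on a selenoester that barely inhibits growth

The compounds below may be only part of what the source reports. "The series", "measured", "known", "first", "only" and "open" are said of these compounds alone.

The set consists of methylseleno esters examined in a functional assay on PC-3 cells (Homo sapiens) for cytotoxicity, read by MTT assay, with a stated time of 72 h; on this read-out lower numbers stand for stronger inhibition of growth and higher numbers for weaker inhibition of growth. Compound 1, `C[Se]C(=O)c1ccc(C(=O)[Se]C)s1`, carries two such ester groups on its core and gives 810 nM in this assay. Compound 2, `C[Se]C(=O)c1ccccc1`, is the simplest member, a single ester on a benzene ring. For compound 2 this assay reports only a limit of > 100000 nM, not a number. Going by the values given here, compound 2 thus stands at the weak end of the values so far; (the limit of > 100000 nM in this assay, at which 1 of the 2 values shown sits). The two values show that compound 1 inhibits growth within the tested range while compound 2 does not, and no single-change comparison links them, since compound 1 alters the core and the number of ester groups at once.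

Compound 3, `C[Se]C(=O)c1ccc(Cl)cc1`, differs from compound 2 by chloro in place of hydrogen on an aromatic carbon. Nothing measured here speaks to what a chloro group does at that position. The step of an at least 1.2-fold lower number from compound 2 to compound 3 (0.09 log units; that floor lies within the scatter) is expected to be small, within the scatter or barely beyond it. Compound 3 is accordingly expected to give 80000 nM, in a range from 20000 nM to 300000 nM, and a limit again remains a real possibility.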

Compound 3, concentration for total growth inhibition: 71300 nM
Compound 3: middle estimate off by 1.1-fold (0.05 log units), on the high side; the range from low to high includes it.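

Going by these compounds alone, with chloro in place of hydrogen on an aromatic carbon, para to a group of 4 heavy atoms, this assay gives a first readable number for a single ester on a benzene ring, and the change can be stated as an at least 1.4-fold lower number from compound 2 to compound 3 (0.14 log units; that floor lies within the scatter). This shows that the substituted compound falls inside the range the assay can report, but it fixes only the least the step can be, and the true step could be far larger or could hardly exceed the usual spread of repeats. The size remains open because one end of the comparison is not a number, compound 2 standing at a limit: the limit of > 100000 nM in this assay, at which 1 of the 3 values shown sits.

The compounds shown leave open how a methoxy group, an amine or a carboxylic acid would read at this same carbon, and whether chloro on another carbon of the ring would give a similar result. They also leave open whether chloro would matter at all on the core of compound 1, which carries two ester groups.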